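A few compounds are considered here, and "the series" means these few. Any claim that something is new, unique, unknown or untested is made for them only; others in the source may bear on it.

Measured compounds:
Compound 1, `N#CCC(=O)OCCc1c(-c2ccccc2Cl)c2cc(Cl)ccc2[nH]c1=O`: 100000 nM
Compound 2, `CC(=O)OCC(=O)OCCc1c(-c2ccccc2Cl)c2cc(Cl)ccc2[nH]c1=O`: 100000 nM

In an ADME assay on HepG2 2.2.15 cells (Homo sapiens) for cytotoxicity (on this read-out higher numbers stand for lower toxicity in this test and lower numbers for higher toxicity in this test), compound 2 gives 100000 nM, level with compound 1 at the digits shown; the only measured step, no change at the digits printed from compound 1 to compound 2 (within the scatter), lies within the scatter. Compound 3, `COc1ccc(/C=C/C(=O)OCCc2c(-c3ccccc3Cl)c3cc(Cl)ccc3[nH]c2=O)cc1`, differs from compound 2 by 2-(4-methoxyphenyl)ethenyl in place of acetoxymethyl on a carbonyl carbon. Going by the values given here, this change is larger than the one measured step, and no measured step resembles it, so the data give only weak guidance. In this assay compound 3 is expected to show no change at the digits printed from compound 2 to compound 3 (within the scatter), nothing beyond the scatter. The estimate for compound 3 is therefore 100000 nM, between 30000 nM and 100000 nM.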

Compound 3, half-maximal cytotoxic concentration: > 1200000 nM
Compound 3 ended at the assay's limit (the forecaster's own chance of this, stated with the estimate: 40%); at least 12-fold (1.07 log units) between middle value and limit.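

In this assay this position on a carbonyl carbon proves able to move the read-out, which the exchange of cyano for acetoxy had not done: 2-(4-methoxyphenyl)ethenyl gives an at least 12-fold higher number from compound 2 to compound 3 (1.07 log units; beyond the scatter) and also an at least 12-fold higher number from compound 1 to compound 3 (1.07 log units; beyond the scatter). The figure for compound 3 is a limit of the assay and not a number: the limit of > 1200000 nM in this assay, at which 1 of the 3 values shown sits.

From the compounds shown here alone, the true size of these steps therefore stays open. So does the question of whether the same read-out would follow with a plain phenyl, a 4-aminophenyl or a saturated two-carbon chain in place of the 2-(4-methoxyphenyl)ethenyl group.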